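This account rests on a few compounds, and the source may have more. Where it says the series, first, only, none or still open, it means among the compounds named here.

Measured compounds:
compound 1 `COc1ccc2nc(C(=O)Nc3ccc(-c4ccccc4)cc3)c(C)c(O)c2c1` gives 0.56%
compound 2 `Cc1c(C(=O)Nc2ccc(-c3ccccc3)cc2)nc2ccccc2c1O` gives 0.06%
compound 3 `Cc1ccc2nc(C(=O)Nc3c(F)cc(-c4cccc(F)c4)cc3F)c(C)c(C(=O)O)c2c1` gives 0.02%

In a functional assay on A-375 cells (Homo sapiens) for antiproliferative activity, read by MTT assay, with a stated time of 24 h, tested at 0.02 ug/mL (a lower number here means a weaker effect, a higher number a stronger effect of the compound at the concentration tested), compound 1 stands within the scatter of both compound 2 and compound 3, so no order among the three can be drawn from these numbers. Within the data shown here, the only single-point step known, a number 0.5 percentage points lower from compound 1 to compound 2 (within the scatter), lies within the scatter as well. Compound 4 `COc1ccc2nc(C(=O)Nc3ccc(-c4ccccc4)cc3)c(C)c(C(=O)O)c2c1` arises from compound 1 by the change (carboxy in place of hydroxy on an aromatic carbon). Among the measured compounds shown here, no measured step bears directly on this change; compound 3, which also carries a carboxy group, shows only that its value and that of compound 1 lie within the scatter of each other. Compound 4 is therefore expected to show no step beyond the scatter, a number 0.3 percentage points lower from compound 1 to compound 4 (within the scatter). The estimate for compound 4 is 0.3%, within 0% to 5%.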

Compound 4, a percentage reported as inhibition, at one concentration (the size of the read-out at that concentration, not a potency): 0.68%
Compound 4: the middle estimate sits 0.4 percentage points below what was measured; the measured number falls inside the stated range.
By their numbers in this assay, from the lowest: compounds 3, 2, 1 and 4 (each within the scatter of the next).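

In this assay the change to carboxy in place of hydroxy on this aromatic carbon, opposite the ring nitrogen, can now be read directly (a number 0.1 percentage points higher from compound 1 to compound 4 (within the scatter)). The step lies within the scatter, so at the single concentration tested this position shows no separation between the two groups. No measured evidence bears on this result. The compounds shown leave open whether an amine or a longer chain at this position would give a step beyond the scatter, and whether this change would separate compound 1 and compound 4 at another concentration.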